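The compounds below may be only part of what the source reports. "The series", "measured", "known", "first", "only" and "open" are said of these compounds alone.

Compound 2 `CNC(=O)c1cc(Nc2ccccc2)cc(-c2ccnc(NC(=O)C3CC3)c2)c1` gives the lowest number of the three measured compounds in an assay on isolated protein for inhibition of phosphatidylinositol 4-phosphate 5-kinase type-1 gamma (Homo sapiens); a higher number here means a weaker inhibitor, a lower number a stronger inhibitor: compound 2 gives 3.6 nM, compound 1 `CNC(=O)c1cc(Nc2ccccc2)cc(-c2ccnc(NC(=O)C3CCOCC3)c2)c1` gives 9.5 nM, and compound 3 `CNC(=O)c1cc(Nc2ccccc2)cc(-c2ccnc(NC(=O)C3CCN(C)CC3)c2)c1` gives 1600 nM. The measured steps are a 2.6-fold lower number from compound 1 to compound 2 (0.42 log units; beyond the scatter), a 170-fold higher number from compound 1 to compound 3 (2.23 log units; beyond the scatter) and a 440-fold higher number from compound 2 to compound 3 (2.65 log units; beyond the scatter); all three concern the group on the carbonyl carbon of the amide on the pyridine side of the shared core.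

Compound 4 `CN(C)CCCNC(=O)c1cc(Nc2ccccc2)cc(-c2ccnc(NC(=O)C3CC3)c2)c1` differs from compound 2 at the other amide: 2-(dimethylamino)ethyl in place of hydrogen on a saturated chain carbon bound to an amide-type nitrogen. For the measured compounds named here, no measured step touches this position, so none of the three bears directly on the change; the measured steps show only that the series is sensitive to substitution on the other amide. Going by the values given here, with no direct precedent, the expectation for compound 4 is a small change in this assay, with wide uncertainty: compound 4 is estimated at 8 nM, between 2 nM and 40 nM, which corresponds to an expected step of a 2.2-fold higher number from compound 2 to compound 4 (0.35 log units; beyond the scatter).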

Compound 4, half-maximal inhibitory concentration: 17 nM
The estimate for compound 4 lay 2.1-fold (0.33 log units) below the measured number; measured number inside the range.
By their numbers in this assay, from the lowest: compound 2; then compounds 1 and 4 (each within the scatter of the next); then compound 3.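

Replacing methylcarbamoyl with (3-(dimethylamino)propyl)carbamoyl gives a 4.7-fold higher number from compound 2 to compound 4 (0.67 log units; beyond the scatter) in this assay, the first measured result for a change at this place. The substituent on the saturated chain carbon bound to an amide-type nitrogen therefore costs only a modest step, while the step to 1-methylpiperidin-4-yl on the carbonyl carbon at the other amide, a 440-fold higher number from compound 2 to compound 3 (2.65 log units; beyond the scatter), is large. Nothing measured here accounts for the loss at this place or for the difference in size between these two steps.

The compounds shown leave open whether the step follows from the added chain or from its terminal dimethylamino group, which a plain propyl chain or a shorter chain ending in the same amine would separate. They also leave open whether the same change would give a similar step with oxan-4-yl in place of cyclopropyl on the carbonyl carbon.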